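The source may report more compounds than this note shows. Statements on the series, on what has been measured and on what is new or still open speak of the compounds shown alone.

Measured compounds:
- compound 1, `Nc1cc(N)c2nc(-c3ccccc3)c(Oc3ccc(Cl)c(Cl)c3)nc2c1`: 24500 nM
- compound 2, `COc1cc(CNc2nc3cc(N)cc(N)c3nc2-c2ccccc2)cc(OC)c1OC`: 6310 nM
- compound 3, `CCOC(=O)[C@H](CCC(=O)O)NC(=O)c1ccc(Oc2nc3cc(N)cc(N)c3nc2-c2ccccc2)cc1`: 6310 nM

All three share a core carrying two amino groups and a phenyl group, and differ only in what hangs off the remaining position. In a functional assay on TK-10 cells (Homo sapiens) for inhibition, read by sulforhodamine B assay, with a stated time of 48 h (a higher number here means a weaker inhibitor of growth, a lower number a stronger inhibitor of growth), compound 1 gives 24500 nM, the highest of the three numbers, and therefore the weakest growth inhibitor among them. Compound 2 and compound 3 both sit lower, each by a gap beyond the usual scatter, so compound 1 stands apart from them as a weaker inhibitor.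

Compound 4, `Nc1cc(N)c2nc(-c3ccccc3)c(Oc3ccc(F)cc3)nc2c1`, has not yet been tested. It differs from compound 1 in one place: 4-fluorophenyl in place of 3,4-dichlorophenyl on an oxygen on an aromatic ring. Going by the values given here, no pair of measured compounds shows this change, so there is no measured step to lean on. The expected step in this assay is therefore set at about none beyond the scatter, in either direction, with a wide allowance around it: a 1.0-fold higher number from compound 1 to compound 4 (0.01 log units; within the scatter). On that basis compound 4 is estimated to give 25000 nM, within a range from 8000 nM to 80000 nM.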

Compound 4, concentration for 50% growth inhibition: 16600 nM
For compound 4 the middle estimate is 1.5-fold (0.18 log units) above the measured one; measured number inside the range.
By their numbers in this assay, from the lowest: compounds 2 and 3 (each within the scatter of the next); then compounds 4 and 1 (each within the scatter of the next).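

In this assay, placing 4-fluorophenyl in place of 3,4-dichlorophenyl on the oxygen gives a 1.5-fold lower number from compound 1 to compound 4 (0.17 log units; within the scatter) and so leaves the growth-inhibition reading effectively unchanged. Going by these compounds alone, the earlier compounds offered no pair differing in one place, so this is the first direct reading at this position: for this one pair, the halogens on the ring attached through the oxygen can be exchanged in this way without a change that stands out from ordinary repeat variation. No measured evidence shown here offers an explanation for this result.

This single step also swaps two things at once, the two chlorines going and a fluorine arriving, so the compounds shown cannot say what each of those edits does alone, as a phenyl ring with no halogen or with a single chlorine could. Nor do they show whether this position responds to groups of a different kind, such as a nitrile or a morpholine on that ring, so the tolerance seen here cannot be extended beyond these two halogen patterns.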